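Pyridinyl isomer exchange on the shared core

The source may report more compounds than this note shows. Statements on the series, on what has been measured and on what is new or still open speak of the compounds shown alone.

Measured so far:
compound 1 `Cc1cn2c(/C=N/NC(=N)N)c(-c3cccnc3)nc2s1`: 13800 nM
compound 2 `N=C(N)N/N=C/c1c(-c2cccnc2)nc2sc(Cl)cn12`: 20000 nM

In a functional assay on NSCLC cells (Homo sapiens) for antiproliferative activity (on this read-out higher numbers stand for weaker inhibition of growth and lower numbers for stronger inhibition of growth), compound 1 gives 13800 nM, the lowest of the two numbers, with compound 2 nearest at 20000 nM; the step of a 1.4-fold higher number from compound 1 to compound 2 (0.16 log units; within the scatter) leaves the pair indistinguishable. Compound 3 `Cc1cn2c(/C=N/NC(=N)N)c(-c3ccccn3)nc2s1` differs from compound 1 in one place: pyridin-2-yl in place of pyridin-3-yl on an aromatic carbon. Among the measured compounds shown here, no measured step bears on this change: the only step recorded, chloro in place of methyl, touches another part of the core and says nothing about moving the ring nitrogen of the pyridinyl. The change is treated as neutral, so the step from compound 1 to compound 3 is expected to be a 1.0-fold higher number from compound 1 to compound 3 (0.01 log units; within the scatter), none beyond the scatter, but with a wide range for lack of any guiding step. Compound 3 is therefore estimated at 14000 nM, between 4000 nM and 50000 nM.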

Compound 3, concentration for 50% growth inhibition: 10200 nM
The estimate for compound 3 lay 1.4-fold (0.14 log units) above the measured number, and the stated range covers the measured number.
By their numbers in this assay, from the lowest: compounds 3, 1 and 2 (each within the scatter of the next).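

Among the compounds shown here, with pyridin-2-yl in place of pyridin-3-yl on the aromatic carbon, this is the first change at this position, and in this assay it gives a 1.4-fold lower number from compound 1 to compound 3 (0.13 log units; within the scatter). Relocating the ring nitrogen of the pyridinyl therefore leaves the read-out indistinguishable from no change for this pair, so this position shows no preference between these two isomers on the methyl-bearing core. No measured data bear on why the two isomers read alike.

Still open, as far as these compounds go, is whether pyridin-4-yl, phenyl or a phenyl carrying a carboxylic acid on this carbon would move the number beyond the scatter. Also open, from the compounds shown here alone, is whether pyridin-2-yl reads the same when chloro replaces methyl on the shared core.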